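Methoxy for chloro on the aryl ring: cytotoxicity notes

This account rests on a few compounds, and the source may have more. Where it says the series, first, only, none or still open, it means among the compounds named here.

Measured so far:
- compound 1 `Fc1ccc([C@@H]2C[C@@H]3Cc4ccc5ccccc5c4N2O3)cc1`: in an ADME assay on THP-1 cells (Homo sapiens) for cytotoxicity, read by MTT assay, with a stated time of 72 h (a higher number here means that more compound is tolerated, a lower number that less compound is tolerated), compound 1 gives > 300000 nM, a limit of the assay.
- compound 2 `Brc1ccc([C@@H]2C[C@@H]3Cc4ccc5ccccc5c4N2O3)cc1`: in this assay compound 2 gives > 250000 nM, also a limit.
- compound 3 `Clc1cccc([C@@H]2C[C@@H]3Cc4ccc5ccccc5c4N2O3)c1`: in this assay compound 3 gives > 300000 nM, again a limit.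

Compound 3 therefore stands at a limit, and the two other values shown are limits as well; no numbered value exists in the set. The steps a step that the two limits leave unreadable from compound 1 to compound 2, a step that the two limits leave unreadable from compound 1 to compound 3 and a step that the two limits leave unreadable from compound 2 to compound 3 cannot be sized, since both ends of each sit at the limit of > 250000 nM in this assay, at which 1 of the 3 values shown sits, or (the limit of > 300000 nM in this assay, at which 2 of the 3 values shown sit).

Compound 4 `COc1cccc([C@@H]2C[C@@H]3Cc4ccc5ccccc5c4N2O3)c1` differs from compound 3 in one place: methoxy in place of chloro on an aromatic carbon. The measured steps all say the same thing: changing the halogen or its position on the aryl ring has not brought any compound below the limit. Nothing among the compounds shown points toward a readable change in this assay for the step to compound 4, so no step beyond the scatter is expected; the estimate is a number no higher from compound 3 to compound 4 (the limit leaves the size open). Compound 4 is expected to give about 300000 nM, between 100000 nM and 300000 nM, most probably reported again as a limit.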

Compound 4, half-maximal cytotoxic concentration: > 300000 nM
Compound 4 was reported as a limit (the forecaster's own chance of this, stated with the estimate: 80%); the middle value lies on the limit itself.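

In this assay compound 4 gives > 300000 nM, a limit. For the compounds shown here, no step linking compound 4 to compound 1, compound 2 or compound 3 can be read, as all four values are limits. The compounds shown leave open at what concentration any of them becomes cytotoxic, and whether methoxy and the halogens differ at all.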